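The source may report more compounds than this note shows. Statements on the series, on what has been measured and on what is new or still open speak of the compounds shown alone.

Of the compounds shown here, three have so far been measured in a functional assay on 3T3-L1 cells (Mus musculus) for inhibition, with a stated time of 20 min, tested at 20 uM; a lower number here means less inhibition, a higher number more inhibition at the concentration tested (going by the name of the read-out). Compound 1 `CC(=O)N(Cc1cn(Cc2cccc(F)c2F)nn1)Cc1cn(S(=O)(=O)c2ccc(C)cc2)c2ccccc12` gives 39.5% in this assay. Compound 3 `Cc1ccc(S(=O)(=O)n2cc(CN(Cc3cn(Cc4cccc(F)c4F)nn3)C(=O)C(F)(F)F)c3ccccc32)cc1` gives 31.9% there. Compound 1 differs from compound 3 by methyl in place of trifluoromethyl on a carbonyl carbon, and this change made a step of a number 7.6 percentage points higher from compound 3 to compound 1 (within the scatter). Compound 2 `O=C(N(Cc1cccc(F)c1F)Cc1cn(S(=O)(=O)c2ccc(F)cc2)c2ccccc12)C(F)(F)F` stands apart from both: in this assay compound 2 gives -52.3%, the lowest of the three numbers, and the difference between its core and the core of compound 3 is not broken down here. Compound 4 `CC(=O)N(Cc1cccc(F)c1F)Cc1cn(S(=O)(=O)c2ccc(F)cc2)c2ccccc12` has not yet been measured in this assay. Compound 4 differs from compound 2 by methyl in place of trifluoromethyl on a carbonyl carbon, the same change as the one from compound 3 to compound 1; it occurs twice among these compounds, and the place is described in the same words in both cases. Because the earlier step of a number 7.6 percentage points higher from compound 3 to compound 1 (within the scatter) stayed within the scatter, the new step is expected to be small as well, estimated at a number 7.3 percentage points higher from compound 2 to compound 4 (within the scatter). The estimate for compound 4 in this assay is -45%, expected to fall between -80% and -5%.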

Compound 4, a percentage reported as inhibition, at one concentration (the size of the read-out at that concentration, not a potency): 25.8%
Compound 4: middle estimate off by 70.8 percentage points, on the low side; measured number outside the range, above it.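

In this assay, methyl in place of trifluoromethyl on a carbonyl carbon gave a large step on the core of compound 2, a number 78.1 percentage points higher from compound 2 to compound 4 (beyond the scatter). The same change therefore did not carry over in size from one core to the other: the same change on two cores in this assay, a number 7.6 percentage points higher (within the scatter) from compound 3 to compound 1 and a number 78.1 percentage points higher (beyond the scatter) from compound 2 to compound 4, 70.5 percentage points apart, beyond the scatter of two such steps. This shows that, for these two pairs, a step read on one core could not be transferred to the other, but it does not show which part of the cores goes with the gap, as they differ in more than one place and no pair shown separates those places.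

The compounds shown carry only methyl or trifluoromethyl on the carbonyl carbon, leaving open how a longer chain such as propyl, or an amine, would behave there on either core. On these data alone, it also remains open whether the change would give a large step or a small one on any third core.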